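The source may report more compounds than this note shows. Statements on the series, on what has been measured and on what is new or still open speak of the compounds shown alone.

Compound 2 `O=C(CCCN1CCN(c2ccc(F)cc2)CC1)Nc1ccc(Cl)cc1` gives 76.1% in an assay on HEK293 cells for inhibition of Voltage-dependent T-type calcium channel subunit alpha-1G (Homo sapiens), read by patch clamp, tested at 10 uM (on this read-out lower numbers stand for less inhibition and higher numbers for more inhibition at the one concentration tested (going by the name of the read-out)), the lowest of the three measured numbers. Compound 3 `COc1ccccc1N1CCN(CCCC(=O)Nc2ccc(Cl)cc2)CC1` comes nearest to it, giving 84.3% in this assay, and compound 1 `O=C(CCCCN1CCN(c2cccc(Cl)c2)CC1)Nc1ccccc1Cl` lies furthest from it, giving 93.2% in this assay. The unmeasured compound 4 `COc1cccc(N2CCN(CCCC(=O)Nc3ccc(Cl)cc3)CC2)c1` differs from compound 2 in one place: 3-methoxyphenyl in place of 4-fluorophenyl on an amine nitrogen in a ring. Among the measured compounds shown here, only one measured step resembles this change, the one from compound 2 to compound 3, where a 2-methoxyphenyl replaced the 4-fluorophenyl on the same ring nitrogen; that step was a number 8.2 percentage points higher from compound 2 to compound 3 (within the scatter), within the scatter. Compound 1 also carries a different aryl group on the ring nitrogen, yet it differs from compound 2 in more than one place, so its value is not a guide to a single change. Compound 4 is therefore expected to move from compound 2 by a number 7.9 percentage points higher from compound 2 to compound 4 (within the scatter), an expected step not beyond the scatter. The estimate for compound 4 in this assay is 84%, with a range from 72% to 94%.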

Compound 4, a percentage reported as inhibition, at one concentration (the size of the read-out at that concentration, not a potency): 84.1%
Compound 4: middle estimate off by 0.1 percentage points, on the low side; low and high end bracket the measured number.
By their numbers in this assay, from the lowest: compounds 2, 4, 3 and 1 (each within the scatter of the next, the first and the last beyond it).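

Setting 3-methoxyphenyl in place of 4-fluorophenyl on the ring nitrogen gave a number 8 percentage points higher from compound 2 to compound 4 (within the scatter) in this assay, so a second methoxyphenyl group joins the 2-methoxyphenyl group in a step that stays inside the scatter. The new comparison is the one of 3-methoxyphenyl in place of 2-methoxyphenyl, which gave a number 0.2 percentage points lower from compound 3 to compound 4 (within the scatter) and shows that these two groups cannot be told apart in this read-out. No measurement is at hand that would explain these numbers.

The compounds shown leave open whether a carboxylic acid or an amine on this aryl ring would give a step beyond the scatter. They also leave open what a longer chain alone would do: compound 1 carries one, but it differs from the others in more than one place.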